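The source may report more compounds than this note shows. Statements on the series, on what has been measured and on what is new or still open speak of the compounds shown alone.

Of the compounds shown here, three built on a shared core have been tested in an ADME assay on L6 cells (Rattus norvegicus) for cytotoxicity, read by resazurin assay, with a stated time of 72 h; a lower number here means a stronger inhibitor, a higher number a weaker inhibitor. Compound 1 `O=[N+]([O-])c1cn2c(n1)OC[C@H](OCc1ccc(-c3ccc(OC(F)(F)F)cc3Cl)cc1)C2` carries a trifluoromethoxy group where compound 2 `O=[N+]([O-])c1cn2c(n1)OC[C@H](OCc1ccc(-c3ccc(C(F)(F)F)cc3Cl)cc1)C2` carries a trifluoromethyl group. In this assay compound 1 gives 25000 nM, and in this assay compound 2 gives 29000 nM. The change from compound 2 to compound 1 is trifluoromethoxy in place of trifluoromethyl on an aromatic carbon and it gave a 1.2-fold lower number from compound 2 to compound 1 (0.06 log units; within the scatter). Compound 3 `O=[N+]([O-])c1cn2c(n1)OC[C@@H](OCC#Cc1ccc(-c3ccc(C(F)(F)F)cc3)cn1)C2` has a different core from compound 2, and how the two cores differ is not broken down here. In this assay compound 3 reaches only the limit of > 100000 nM, so no number is known for it. One of the three values is such a limit (the limit of > 100000 nM in this assay, at which 1 of the 3 values shown sits).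

Compound 4 `O=[N+]([O-])c1cn2c(n1)OC[C@@H](OCC#Cc1ccc(-c3ccc(OC(F)(F)F)cc3)cn1)C2` has not yet been measured. It stands to compound 3 as compound 1 stands to compound 2: trifluoromethoxy in place of trifluoromethyl on an aromatic carbon. This is the same kind of change, not the same change, as the surroundings differ: in compound 1 the group sits meta to a chloro group and para to a large group, whereas in compound 4 it sits para to a large group. Given that the step from compound 2 to compound 1 was a 1.2-fold lower number from compound 2 to compound 1 (0.06 log units; within the scatter), the expected step from compound 3 to compound 4 is a number no higher from compound 3 to compound 4 (the limit leaves the size open). Compound 4 is estimated at 100000 nM. For compound 4 the expected range runs from 50000 nM to 200000 nM. Compound 4 is also expected, more likely than not, to return only a limit rather than a number.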

Compound 4, half-maximal inhibitory concentration: > 100000 nM
Compound 4: no number, only a limit (the forecaster's own chance of this, stated with the estimate: 75%); the middle value sits exactly at the limit.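

Compound 3 and compound 4 each return only a limit in this assay, not a number, so no step can be read between them. The count of such limits now stands as follows: the limit of > 100000 nM in this assay, at which 2 of the 4 values shown sit. The compounds shown leave open where the true values of compound 3 and compound 4 lie, and whether trifluoromethoxy in place of trifluoromethyl makes any difference on their shared core.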